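The source may hold more compounds than are shown below. What is called first, only, known or untested is meant among the compounds shown, and "the series" means these compounds.

Of the compounds shown here, three built on a shared core have been measured in an in vitro functional assay on cells for agonist activity at Bombesin receptor subtype-3 (Homo sapiens), read by luminescence and calcium flux; a lower number here means that less compound is needed, a higher number that more compound is needed for the effect. Compound 1, `CCCCc1cnc(C(C)Cc2ccc(-c3ccccc3C(=O)O)cc2)[nH]1`, gives 2760 nM. Compound 2, `CCCCc1cnc(CCCc2ccc(-c3ccccc3C(=O)O)cc2)[nH]1`, gives 5600 nM. Compound 3, `COc1ccc(Cc2cnc(CCc3ccc(-c4ccccc4C(=O)O)cc3)[nH]2)cc1`, gives 5360 nM. Among these three numbers, the one for compound 3 lies close to that of compound 2 and somewhat further from that of compound 1, yet both of those gaps stay within the usual scatter of repeated measurements, so the three compounds cannot be told apart on this evidence.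

Compound 4, `O=C(O)c1ccccc1-c1ccc(CCc2ncc(Cc3ccc(F)cc3)[nH]2)cc1`, has not yet been measured. It differs from compound 3 in a single place: fluoro in place of methoxy on an aromatic carbon. For the measured compounds named here, no measured pair among the three known compounds shows this kind of exchange, so there is no directly comparable step to lean on. With a change this small at the outer edge of the molecule, the expectation is a step of a 1.1-fold lower number from compound 3 to compound 4 (0.03 log units; within the scatter), that is, nothing beyond the scatter. For compound 4 the estimated value in this assay is 5000 nM, with a likely range from 2000 nM to 13000 nM.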

Compound 4, half-maximal effective concentration: 1600 nM
Beside the measured number, compound 4's estimate is 3.1-fold (0.49 log units) above it, and the stated range ends above it.
By their numbers in this assay, from the lowest: compounds 4, 1, 3 and 2 (each within the scatter of the next, the first and the last beyond it).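

In this assay the exchange of 4-methoxybenzyl for 4-fluorobenzyl gives a 3.4-fold lower number from compound 3 to compound 4 (0.53 log units; beyond the scatter) and shows that this position, para to a large group, responds to a single small exchange. The earlier compounds shown here could not show this, as no two of them differ in just one place. This is a modest step, but it lies beyond the usual scatter, and nothing measured here explains it.

Methoxy and fluoro are the only groups compared at this position, so it remains open whether chloro, trifluoromethyl or a plain hydrogen there would give a lower or a higher number. Also open, going by these compounds, is whether the same exchange would give a step of similar size on another compound of this series.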